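This account rests on a few compounds, and the source may have more. Where it says the series, first, only, none or still open, it means among the compounds named here.

Three close relatives of one shared core have so far been tested in an ADME assay on BJ cells (Homo sapiens) for cytotoxicity, with a stated time of 72 h; on this read-out higher numbers stand for an effect only at larger amounts of compound and lower numbers for an effect already at smaller amounts. Compound 1, `Cc1ccc(NC(=O)Nc2cc(C)nc3ccccc23)cc1`, reports only a limit there, namely > 25000 nM. Compound 2, `Cc1cc(NC(=O)Nc2cccc(Cl)c2)c2ccccc2n1`, likewise reports only a limit, > 25000 nM. Compound 3, `Cc1cc(NC(=O)Nc2cc(Cl)cc(Cl)c2)c2ccccc2n1`, also stops at a limit, > 25000 nM. Because every one of these results rests at the limit of > 25000 nM in this assay, at which 3 of the 3 values shown sit, neither connecting step can be sized: between the first two compounds lies a step that the two limits leave unreadable from compound 1 to compound 2, and between the next two lies a step that the two limits leave unreadable from compound 2 to compound 3. Compound 2 therefore stands exactly where its neighbours stand, at the limit, with no number of its own.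

Compound 4, `Cc1cc(NC(=O)Nc2cccc(OC(F)(F)F)c2)c2ccccc2n1`, is not yet measured. It differs from compound 2 in a single place: trifluoromethoxy in place of chloro on an aromatic carbon. Among the compounds with values here, the two measured steps bear on this change only by showing that this assay reached its limit for every related compound so far; they give no readable size in either direction. Nothing in the data points to a step beyond the usual scatter, and another limit is the most likely outcome. The estimated step is a step that the limit leaves unreadable from compound 2 to compound 4. Compound 4 is accordingly expected to give about 30000 nM in this assay, within a range from 12000 nM to 100000 nM.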

Compound 4, half-maximal effective concentration: 25000 nM
Compound 4: the middle estimate sits 1.2-fold (0.08 log units) above what was measured; low and high end bracket the measured number.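

In this assay, compound 4 is the only one of the compounds shown to report a plain number, 25000 nM, and not a limit. Putting trifluoromethoxy in place of chloro, on an aromatic carbon meta to a large group, swaps one heavy atom for five and adds a hydrogen-bond acceptor, and the result is a number no higher from compound 2 to compound 4 (the limit leaves the size open), so this change can be described only by its possible direction and not by its size. The number for compound 4 also falls exactly where the other compounds stop, so it gives no sign of a clear effect at smaller amounts of compound: the limit of > 25000 nM in this assay, at which 3 of the 4 values shown sit.

None of the steps in this small series can be read as a size, so the effect of this position on this assay is still unmeasured. From the compounds shown here alone, whether an amine, a carboxylic acid or a longer chain on the same aromatic carbon would bring the number clearly below that of compound 4 stays open.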